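Trifluoromethylphenyl Amide Estimated From Three Methoxyphenyl Analogues

The source may report more compounds than this note shows. Statements on the series, on what has been measured and on what is new or still open speak of the compounds shown alone.

Three amides built on a shared core have been examined in an assay (strain Wistar) for displacement of a labelled ligand from adenosine receptor A1 (Rattus norvegicus), read by scintillation counting; on this read-out higher numbers stand for weaker inhibition and lower numbers for stronger inhibition. Compound 1 `COc1ccccc1C(=O)Nc1nc(-c2ccccc2)nc2c1nnn2Cc1ccccc1` gives 1520 nM, the lowest number of the three. Compound 2 `CCOc1ccccc1C(=O)Nc1nc(-c2ccccc2)nc2c1nnn2Cc1ccccc1` gives 1850 nM, and the step of a 1.2-fold higher number from compound 1 to compound 2 (0.09 log units; within the scatter) stays within the scatter. Compound 3 `COc1ccc(Cl)cc1C(=O)Nc1nc(-c2ccccc2)nc2c1nnn2Cc1ccccc1` gives 7150 nM; the step of a 4.7-fold higher number from compound 1 to compound 3 (0.67 log units; beyond the scatter) lies beyond the scatter, as does a 3.9-fold higher number from compound 2 to compound 3 (0.59 log units; beyond the scatter).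

Compound 4 `O=C(Nc1nc(-c2ccccc2)nc2c1nnn2Cc1ccccc1)c1cccc(C(F)(F)F)c1` has not yet been measured. It differs from compound 1 in one place: 3-(trifluoromethyl)phenyl in place of 2-methoxyphenyl on a carbonyl carbon. Within the data shown here, no measured step exchanges the whole aryl group, so the guidance is indirect. Among the measured compounds shown here, the nearest precedent is a 4.7-fold higher number from compound 1 to compound 3 (0.67 log units; beyond the scatter), where adding a chloro to the ring weakened binding modestly, while a 1.2-fold higher number from compound 1 to compound 2 (0.09 log units; within the scatter) shows that a small change at the alkoxy group does nothing beyond the scatter. A modest weakening is therefore expected in this assay, estimated as a 2.3-fold higher number from compound 1 to compound 4 (0.36 log units; beyond the scatter). Compound 4 is accordingly expected to give 3500 nM, within a range from 900 nM to 14000 nM.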

Compound 4, inhibition constant: 163 nM
Estimate against measurement, compound 4: 21-fold (1.33 log units) above; the measured number lies below the stated range.
By their numbers in this assay, from the lowest: compound 4; then compounds 1 and 2 (each within the scatter of the next); then compound 3.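

At this carbonyl carbon, changing the aryl group can lower the number as well as raise it: in this assay the exchange for 3-(trifluoromethyl)phenyl gives a 9.3-fold lower number from compound 1 to compound 4 (0.97 log units; beyond the scatter) and likewise an 11-fold lower number from compound 2 to compound 4 (1.05 log units; beyond the scatter) and a 44-fold lower number from compound 3 to compound 4 (1.64 log units; beyond the scatter) with the largest step starting from the chloro compound. The earlier compounds, all carrying an alkoxy group on the ring, had shown only a step within the scatter or steps to higher numbers, whereas compound 4 stands beyond the scatter of all three as the strongest inhibitor here. No evidence is available to account for this result.

The exchange removes the methoxy group and brings in the trifluoromethyl group at once, and the compounds shown do not separate these two changes. As far as these compounds go, whether a plain phenyl group or a cyanophenyl group on the same carbonyl carbon would also give a low number remains open.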